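Trimethoxyphenyl pyrazole chalcones: swapping the aryl ketone

A few compounds are considered here, and "the series" means these few. Any claim that something is new, unique, unknown or untested is made for them only; others in the source may bear on it.

Measured compounds:
compound 1 `COc1cc(-c2cc(/C=C/C(=O)c3ccc(N)cc3)[nH]n2)cc(OC)c1OC`: 67%
compound 2 `COc1cc(-c2cc(/C=C/C(=O)c3ccc(Cl)c(Cl)c3)[nH]n2)cc(OC)c1OC`: 81%
compound 3 `COc1ccc(C(=O)/C=C/c2cc(-c3cc(OC)c(OC)c(OC)c3)n[nH]2)cc1`: 67%

In a functional assay on RXF 393 cells (Homo sapiens) for cytotoxicity, read by sulforhodamine B assay, with a stated time of 48 h, tested at 1 uM (a lower number here means a stronger effect, a higher number a weaker effect of the compound at the concentration tested), compound 3 gives 67%, level with compound 1 at the digits shown; together they are the lowest two of three numbers, with compound 2 the only one beyond the scatter from them, a number 14 percentage points lower from compound 2 to compound 3 (beyond the scatter).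

Compound 4 `COc1cc(-c2cc(/C=C/C(=O)c3ccc(F)c(F)c3)[nH]n2)cc(OC)c1OC` differs from compound 3 by 3,4-difluorophenyl in place of 4-methoxyphenyl on a carbonyl carbon. The closest comparison is the step of a number 14 percentage points lower from compound 2 to compound 3 (beyond the scatter), where 3,4-dichlorophenyl was traded for 4-methoxyphenyl on the same carbonyl carbon. Compound 4 goes back towards a dihalogenated ring, so a step of roughly that size but upward in this assay is expected, a weaker effect, though possibly smaller. Compound 4 is estimated at 76%, in the range 64% to 88%, meaning the step of a number 9 percentage points higher from compound 3 to compound 4 (within the scatter).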

Compound 4, a percentage reported as activity, at one concentration (the size of the read-out at that concentration, not a potency): 82%
Estimate against measurement, compound 4: 6 percentage points below; measured number inside the range.
By their numbers in this assay, from the lowest: compounds 1 and 3 (each within the scatter of the next); then compounds 2 and 4 (each within the scatter of the next).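

In this assay the 3,4-difluorophenyl ring of compound 4 reads like the 3,4-dichlorophenyl ring of compound 2 (a number 1 percentage points higher from compound 2 to compound 4 (within the scatter)), so exchanging one halogen for the other on this ring makes no visible difference. Both dihalogenated compounds give the weaker effect, since the 3,4-difluorophenyl ring also separates from 4-methoxyphenyl (a number 15 percentage points higher from compound 3 to compound 4 (beyond the scatter)) and from 4-aminophenyl (a number 15 percentage points higher from compound 1 to compound 4 (beyond the scatter)). Nothing available explains this split into two pairs. On these data alone, whether it follows the two halogens or the amino and methoxy groups stays open. A plain phenyl or a 4-chlorophenyl ring on the same carbonyl carbon would help to separate these readings.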